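Swapping the vinyl iodide for a chloride on a brominated lactone

This account rests on a few compounds, and the source may have more. Where it says the series, first, only, none or still open, it means among the compounds named here.

Of the compounds shown here, three of a shared core have been tested in a functional assay on KB cells (Homo sapiens) for cytotoxicity; on this read-out lower numbers stand for an effect already at smaller amounts and higher numbers for an effect only at larger amounts of compound. Compound 1, `CCCCC1=C(Br)/C(=C/Br)OC1=O`, reaches only the limit of the measurement: in this assay compound 1 gives > 20 ug/mL, a limit rather than a number (the limit of > 20 ug/mL in this assay, at which 1 of the 3 values shown sits). Compound 2, `CCC[C@@H](O)C1=C(Br)/C(=C/I)OC1=O`, gives 0.4 ug/mL in this assay, the highest of the two numbers actually measured. Among the measured compounds shown here, compound 3, `CCC[C@@H](OC(C)=O)C1=C(Br)/C(=C/I)OC1=O`, gives 0.1 ug/mL; the step of a 4.0-fold lower number from compound 2 to compound 3 (0.60 log units; beyond the scatter) is the only measured step and it concerns the oxygen on the saturated carbon, not the halogen.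

Compound 4, `CCC[C@@H](O)C1=C(Br)/C(=C/Cl)OC1=O`, is not yet measured. Its change from compound 2 is chloro in place of iodo on a double-bonded chain carbon bound to a double-bonded ring carbon. For the measured compounds named here, no measured step touches this position, so the measured steps give no direction for it; compound 1 carries a different halogen there but also differs in another place, so its limit cannot be read as a halogen effect. The expectation is therefore a step of a 2.0-fold higher number from compound 2 to compound 4 (0.30 log units; within the scatter), near the scatter. Compound 4 is estimated at 0.8 ug/mL, with a range from 0.2 ug/mL to 3.5 ug/mL.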

Compound 4, concentration for half-maximal effect: 0.4 ug/mL
Estimate against measurement, compound 4: 2.0-fold (0.30 log units) above; the range from low to high includes it.
By their numbers in this assay, from the lowest: compound 3; then compounds 2 and 4 (each within the scatter of the next). At a limit, above all of these: compound 1.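

In this assay, among the compounds shown here, this is the first measured change at the double-bonded chain carbon bound to a double-bonded ring carbon, and it reads no change at the digits printed from compound 2 to compound 4 (within the scatter). With the rest of the structure held fixed, chloro can therefore stand in place of iodo at this position with no shift beyond the scatter, so iodo is not required for the effect of compound 2 on these cells. Nothing shown explains why the two halogens give the same number.

Compound 1 carries bromo at this position but also differs in another place, and its > 20 ug/mL is a limit, so it does not show what bromo alone would do. Also open, from the compounds shown here alone, is how a nitrile or an amine would fare at this position, and whether the acetyl group of compound 3 would give the same step alongside chloro.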